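The source may hold more compounds than are shown below. What is called first, only, known or untested is meant among the compounds shown, and "the series" means these compounds.

Within the data shown here, compound 1 `CCCc1nc(-c2ccccc2)c(CNCCN2CCN(c3cccc(C)c3)CC2)o1` gives 43.1% in an assay on HEK293 cells for inhibition of Voltage-dependent T-type calcium channel subunit alpha-1G (Homo sapiens), read by fluorescence, tested at 10 uM (on this read-out lower numbers stand for less inhibition and higher numbers for more inhibition at the one concentration tested (going by the name of the read-out)), the lowest of the two numbers measured so far; compound 2 `CCCc1nc(-c2ccccc2)c(CNCCCN2CCN(c3cccc(F)c3)CC2)o1` gives 68.9%, a reading that stands beyond the scatter above it. Compound 3 `CCCc1nc(-c2ccccc2)c(CNCCN2CCN(c3ccc(C(F)(F)F)cc3)CC2)o1` differs from compound 1 by one change: 4-(trifluoromethyl)phenyl in place of 3-methylphenyl on an amine nitrogen in a ring. Among the measured compounds shown here, no measured pair carries this change, so its size is unknown from the data. Compound 3 is therefore expected to give about 52%, somewhere between 28% and 76%. The step of a number 8.9 percentage points higher from compound 1 to compound 3 (within the scatter) is expected to be small and upward, possibly still within the scatter.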

Compound 3, a percentage reported as inhibition, at one concentration (the size of the read-out at that concentration, not a potency): 58.7%
Compound 3: middle estimate off by 6.7 percentage points, on the low side; low and high end bracket the measured number.
By their numbers in this assay, from the lowest: compound 1; then compound 3; then compound 2.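

The position on an amine nitrogen in a ring responds to the aryl group it carries in this assay: 4-(trifluoromethyl)phenyl in place of 3-methylphenyl gives a number 15.6 percentage points higher from compound 1 to compound 3 (beyond the scatter), a modest step. The larger group, with its three fluorine atoms, is thus compatible with a higher reading at this position. Nothing measured on these compounds explains the step. Going by these compounds, what a 4-methylphenyl or a 3-(trifluoromethyl)phenyl would give on this nitrogen remains open, so the effect of the substituent cannot yet be separated from that of its place on the phenyl ring.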